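The source may hold more compounds than are shown below. What is called first, only, known or untested is meant among the compounds shown, and "the series" means these compounds.

Measured in an ADME assay on microsomes from liver (Mus musculus) for metabolic stability, read by LC-MS, using NADPH, with stated times of 10 min and 30 min, tested at 1 uM; on this read-out higher numbers stand for fast clearance and lower numbers for slow clearance:
- compound 1 `COC(=O)C1=C(C)NC(c2nccs2)=NC1(C)c1ccc(F)c(F)c1`: 83 mL/min/kg
- compound 2 `COC(=O)C1=C(CN2CCNCC2)NC(c2nccs2)=NC1(C)c1ccc(F)cc1`: 39 mL/min/kg
- compound 3 `COC(=O)C1=C(CN2CCC(O)C2)NC(c2nccs2)=NC1(C)c1ccc(F)cc1`: 83 mL/min/kg

Compound 3 at 83 mL/min/kg stands level with compound 1 at 83 mL/min/kg, and the two share the highest number of the three. Compound 2 is the only one lower, at 39 mL/min/kg.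

The next compound is compound 4 `COC(=O)C1=C(COC2CCOC2)NC(c2nccs2)=NC1(C)c1ccc(F)cc1`, which carries (oxolan-3-yl)oxy in place of 3-hydroxypyrrolidin-1-yl on a saturated chain carbon bound to a double-bonded ring carbon.

For the measured compounds named here, only one measured step changes this same place: a 2.1-fold higher number from compound 2 to compound 3 (0.33 log units; beyond the scatter). It is modest, though beyond the scatter, and it involves a different incoming group. Going by the values given here, no measured compound carries (oxolan-3-yl)oxy, so the direction of the change has no direct support in the data. The two numbers at the top of the series and the modest size of that single step point to compound 4 staying close to compound 3 in this assay, with a slight fall at most.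

The expected change is a 1.2-fold lower number from compound 3 to compound 4 (0.07 log units; within the scatter), which would be no step beyond the scatter. For compound 4 the estimated clearance is 70 mL/min/kg, with an expected range of 40 mL/min/kg to 95 mL/min/kg.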

Compound 4, clearance: 79 mL/min/kg
For compound 4 the middle estimate is 1.1-fold (0.05 log units) below the measured one; measured number inside the range.
By their numbers in this assay, from the lowest: compound 2; then compounds 4, 1 and 3 (each within the scatter of the next).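

In this assay, the change from 3-hydroxypyrrolidin-1-yl to (oxolan-3-yl)oxy on a saturated chain carbon bound to a double-bonded ring carbon gives a 1.1-fold lower number from compound 3 to compound 4 (0.02 log units; within the scatter): the entering group has 0 hydrogen-bond donors against 1 in the leaving group and no nitrogen, yet the two compounds cannot be told apart on this read-out. The other new step, a 2.0-fold higher number from compound 2 to compound 4 (0.31 log units; beyond the scatter), repeats the gap first seen with 3-hydroxypyrrolidin-1-yl, so among the three groups shown at this place, piperazin-1-yl alone carries the lower clearance number, and it now stands apart from two different five-membered rings rather than one. Nothing measured here gives a reason for these numbers.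

With only piperazin-1-yl on the low side, the compounds shown leave open whether that number belongs to its six-membered ring or to its free ring amine, a question that morpholin-4-yl, piperidin-1-yl or 4-methylpiperazin-1-yl at the same place would help to separate. Also open, going by these compounds, is whether an open-chain amine such as dimethylamino on this carbon would sit with compound 2 or with compound 3 and compound 4.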